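The source may hold more compounds than are shown below. What is called first, only, known or untested is meant among the compounds shown, and "the series" means these compounds.

Measured so far in an ADME assay on cells (Hepatocyte, Rattus norvegicus) for metabolic stability; a higher number here means faster removal of the compound, a lower number slower removal:
compound 1 `CNC(=O)CN1CCC(c2cc3c(-c4ccc(=O)n(C(C)C)c4)ccnc3[nH]2)CC1` — 8.9 uL/min
compound 2 `COc1cc(F)ccc1-c1ccnc2[nH]c(C3CCN(CC(=O)N(C)C)CC3)cc12` — 38 uL/min
compound 3 `CC(C)n1cc(-c2ccnc3[nH]c(C4CCN(CC(=O)N(C)C)CC4)cc23)cnc1=O` — 100 uL/min

Compound 1 gives the lowest number of the three; compound 2 is the nearest and compound 3 the furthest, both beyond the scatter. Within the data shown here, the only measured step, a 2.6-fold higher number from compound 2 to compound 3 (0.42 log units; beyond the scatter), changes a group on an aromatic carbon and does not touch the place altered here.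

Compound 4 `CC(C)n1cc(-c2ccnc3[nH]c(C4CCN(Cc5cccs5)CC4)cc23)ccc1=O` differs from compound 1 by thiophen-2-yl in place of methylcarbamoyl on a saturated chain carbon bound to an amine nitrogen in a ring. Among the measured compounds shown here, no measured step covers this change, so the expectation rests only on the range the series spans in this assay. An upward step of roughly a 4.5-fold higher number from compound 1 to compound 4 (0.65 log units; beyond the scatter) is expected, with wide uncertainty. Compound 4 is estimated at 40 uL/min, within 14 uL/min to 120 uL/min.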

Compound 4, intrinsic clearance in a liver preparation (reported as CLH), per the amount of preparation that the assay uses: 43 uL/min
Compound 4: middle estimate off by 1.1-fold (0.03 log units), on the low side; the measured number falls inside the stated range.
By their numbers in this assay, from the lowest: compound 1; then compounds 2 and 4 (each within the scatter of the next); then compound 3.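

In this assay, among these compounds, thiophen-2-yl in place of methylcarbamoyl on a saturated chain carbon bound to an amine nitrogen in a ring gives a 4.8-fold higher number from compound 1 to compound 4 (0.68 log units; beyond the scatter) and is the only measured step at this place. The number therefore responds to this position on the shared core, not only to the group on the aromatic carbon.

On these data alone, whether the step follows from losing methylcarbamoyl or from gaining thiophen-2-yl remains open, as does the reading for a carboxylic acid or a longer chain on this carbon. Nothing available explains the step.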